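The source may report more compounds than this note shows. Statements on the series, on what has been measured and on what is new or still open speak of the compounds shown alone.

Compound 1 `CCCCCCCCCCOc1ccc(-c2c(C)[nH]c(=O)n2C)cc1`: in a functional assay on the whole organism with Rattus norvegicus as the target (a lower number here means that less compound is needed, a higher number that more compound is needed for the effect), compound 1 gives 0.1 mg/kg.
Compound 2 `CCCCCCCCCCCOc1ccc(-c2c(C)[nH]c(=O)n2C)cc1`: in this assay compound 2 gives 0.1 mg/kg.
Compound 3 `CCCCCCCCCCOc1ccc(-c2c(C)[nH]c(=O)n2C2CCCCC2)cc1`: in this assay compound 3 gives 0.1 mg/kg.

Compound 3 stands level with compounds 1 and 2 in this assay, with no difference among the three beyond the scatter. The two measured steps are both flat: no change at the digits printed from compound 1 to compound 2 (within the scatter), and no change at the digits printed from compound 1 to compound 3 (within the scatter). Neither touches the part of the molecule that changes next.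

Compound 4 `Cc1[nH]c(=O)n(C2CCCCC2)c1-c1ccc(OCc2ccccc2)cc1` differs from compound 3 in one place: phenyl in place of nonyl on a saturated chain carbon bound to an oxygen on an aromatic ring. For the measured compounds named here, no measured pair alters this chain, so nothing in the data bears directly on the step. Going by the values given here, the flat steps so far show that the series tolerates changes at the chain end and on the aromatic nitrogen, but the swap to phenyl on the carbon bound to the aromatic oxygen shortens the chain by far more than any measured step, and its effect in this assay is open. The account therefore expects a modest loss, of the order of a 3.0-fold higher number from compound 3 to compound 4 (0.48 log units; beyond the scatter), with wide uncertainty. Compound 4 is estimated in this assay at 0.3 mg/kg, within a range from 0.1 mg/kg to 3 mg/kg.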

Compound 4, minimum effective dose: 0.1 mg/kg
Compound 4: the middle estimate sits 3.0-fold (0.48 log units) above what was measured; the range from low to high includes it.
By their numbers in this assay, from the lowest: compounds 1, 2, 3 and 4 (each within the scatter of the next).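

The step from the decyl chain of compound 3 to the benzyl group of compound 4 shows that this place tolerates far more than a change at the chain end: with phenyl in place of nonyl on a saturated chain carbon bound to an oxygen on an aromatic ring, this assay records no change at the digits printed from compound 3 to compound 4 (within the scatter) despite the loss of most of the chain. The earlier steps shown here had altered this chain only at its far end, so they could not show that a long saturated chain is dispensable here, or that a six-membered aromatic ring of carbon only can stand in its place without a step beyond the scatter. The data offer no explanation for this result.

The compounds shown leave open whether the same holds for other groups at this place, such as a pyridine ring, an amine or a carboxylic acid, or for a short chain such as ethyl. They also leave open whether the benzyl group gives the same reading with methyl rather than cyclohexyl on the aromatic nitrogen.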